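Amine replacement on the saturated ring of the shared core

The source may report more compounds than this note shows. Statements on the series, on what has been measured and on what is new or still open speak of the compounds shown alone.

Measured so far:
compound 1 `O[C@H]1Cc2ccccc2C1NC1CCN(CCCc2c[nH]c3ccc(-n4cnnc4)cc23)CC1` — in an assay on CHO cells for displacement of a labelled ligand from 5-hydroxytryptamine receptor 1D (Homo sapiens) (a higher number here means a weaker inhibitor, a lower number a stronger inhibitor), compound 1 gives 37 nM
compound 2 `CC(C)=CCCN(C)C1CCN(CCCc2c[nH]c3ccc(-n4cnnc4)cc23)CC1` — in this assay compound 2 gives 2.6 nM

For the measured compounds named here, compound 1 stands highest of the two numbers so far. Going by the values given here, the only step recorded, a 14-fold lower number from compound 1 to compound 2 (1.15 log units; beyond the scatter), runs downward and lies beyond the scatter, so compound 2 is the stronger inhibitor of the pair.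

Compound 3 `CC(C)=CCN(C)C1CCN(CCCc2c[nH]c3ccc(-n4cnnc4)cc23)CC1` has not yet been measured. Relative to compound 1 the change is: methyl(3-methylbut-2-en-1-yl)amino in place of (2-hydroxy-2,3-dihydro-1H-inden-1-yl)amino on a saturated ring carbon. Among the compounds with values here, this is closely related to the one measured step: the group that enters in compound 3 is the methyl(3-methylbut-2-en-1-yl)amino relative of the methyl(4-methylpent-3-en-1-yl)amino group that enters in compound 2, and what leaves is the same in both cases. The step of a 14-fold lower number from compound 1 to compound 2 (1.15 log units; beyond the scatter) therefore bears directly on the expectation, and a downward step of comparable size is expected, an 11-fold lower number from compound 1 to compound 3 (1.02 log units; beyond the scatter). Within the data shown here, no measured step distinguishes the two entering chains from each other, so the width of the expectation is set by that lack of a direct comparison.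

The estimate for compound 3 is 3.5 nM, with a range of 1.2 nM to 12 nM.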

Compound 3, half-maximal inhibitory concentration: 0.5 nM
Beside the measured number, compound 3's estimate is 7.0-fold (0.85 log units) above it, and the stated range ends above it.
By their numbers in this assay, from the lowest: compound 3; then compound 2; then compound 1.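

In this assay, the step of a 74-fold lower number from compound 1 to compound 3 (1.87 log units; beyond the scatter) shows that this saturated ring carbon tolerates the open methyl(3-methylbut-2-en-1-yl)amino group in place of the (2-hydroxy-2,3-dihydro-1H-inden-1-yl)amino group, and that the lower number does not depend on the exact chain that compound 2 carries. The step of a 5.2-fold lower number from compound 2 to compound 3 (0.72 log units; beyond the scatter) adds what the earlier pair could not show: the two open-chain tertiary amines are separated beyond the scatter, so the length of the alkenyl chain matters at this position, with the shorter chain of compound 3 giving the lower number. No measurement on hand accounts for either step.

The compounds shown leave open which part of the change from compound 1 carries the step, since the ring, the hydroxyl and the amine hydrogen all leave together while the methyl on the amine nitrogen and the double bond enter together. A saturated 3-methylbutyl chain, or the same 3-methylbut-2-en-1-yl chain on a secondary amine, would separate these contributions, and a still shorter allyl chain would show whether the trend with chain length continues.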